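This account rests on a few compounds, and the source may have more. Where it says the series, first, only, none or still open, it means among the compounds named here.

Measured compounds:
- compound 1, `CC(=O)Oc1ccccc1C(=O)NCC[Se]C#N`: 2100 nM
- compound 2, `CC(=O)Oc1ccccc1C(=O)OCC[Se]C#N`: 20200 nM
- compound 3, `C[Se]CC(NC(=O)c1ccccc1OC(C)=O)C(=O)O`: > 50000 nM (a limit, not a number)

In a functional assay on HT-29 cells (Homo sapiens) for antiproliferative activity, read by MTT assay, with a stated time of 72 h (a lower number here means a stronger inhibitor, a higher number a weaker inhibitor), compound 2 stands at the highest of the two numbers; the nearest is compound 1, and the step of a 9.6-fold higher number from compound 1 to compound 2 (0.98 log units; beyond the scatter) lies beyond the scatter. Compound 3 gives only a limit, the one recorded at the limit of > 50000 nM in this assay, at which 1 of the 3 values shown sits, so it adds no number to compare.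

Compound 4, `CC(=O)Oc1ccccc1C(=O)NCCSC#N`, differs from compound 2 in one place: a group of 6 heavy atoms (3 carbon, 2 nitrogen, 1 sulfur; no ring) in place of a group of 6 heavy atoms (3 carbon, 1 nitrogen, 1 oxygen, 1 selenium; no ring), on a carbonyl carbon. Among the measured compounds shown here, only one measured step bears on this change. From compound 1 to compound 2 the amide became an ester and the number rose by a 9.6-fold higher number from compound 1 to compound 2 (0.98 log units; beyond the scatter); compound 4 goes the other way, back to an amide. For the measured compounds named here, the other half of the change, sulfur in place of selenium, has no measured counterpart here, so its effect is unknown. The step is therefore expected to fall, as a 3.4-fold lower number from compound 2 to compound 4 (0.53 log units; beyond the scatter), though by less than the full amide-to-ester step. Compound 4 is estimated at 6000 nM, within a range of 1500 nM to 25000 nM.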

Compound 4, half-maximal inhibitory concentration: > 50000 nM
Compound 4: a limit, no number; the forecaster's own chance of this, stated with the estimate: 10%; at least 8.3-fold (0.92 log units) between middle value and limit.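

Sulfur in place of selenium, on a saturated chain carbon, two bonds along the chain from an amide-type nitrogen, gives an at least 23-fold higher number from compound 1 to compound 4 (1.37 log units; beyond the scatter) in this assay, the first measured view of this one-atom change. Set against the ester, the (2-(cyanosulfanyl)ethyl)amino group gives an at least 2.4-fold higher number from compound 2 to compound 4 (0.39 log units; beyond the scatter), so returning to the amide does not make up for the loss of selenium. Compound 4 gives only a limit, not a number, which makes both steps minimum sizes, and it sits there with compound 3: the limit of > 50000 nM in this assay, at which 2 of the 4 values shown sit.

From the compounds shown here alone, how much weaker compound 4 really is therefore stays unknown, as does the effect of sulfur on the ester. Also open, going by these compounds, is whether a longer chain carrying the selenium, or an amine in place of the nitrile, would keep the activity of compound 1.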